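A few compounds are considered here, and "the series" means these few. Any claim that something is new, unique, unknown or untested is made for them only; others in the source may bear on it.

The measured compounds:
compound 1 `C=C(C)CCC[C@]1(C)C2=CCC[C@](C)(C[C@@H](O)c3ccoc3)[C@H]2CC[C@H]1C`: 59400 nM
compound 2 `C=C(C)CC[C@]1(C)C2=CCC[C@](C)(C[C@@H](O)c3ccoc3)[C@H]2CC[C@H]1C`: 30200 nM

In a functional assay on HeLa cells (Homo sapiens) for antiproliferative activity, read by XTT assay, with a stated time of 72 h (a higher number here means a weaker inhibitor, a lower number a stronger inhibitor), compound 2 holds the lowest of the two numbers; its nearest neighbour is compound 1, and the step of a 2.0-fold lower number from compound 1 to compound 2 (0.29 log units; within the scatter) lies within the scatter, so the two cannot be ordered.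

Compound 3 `C=C(C)CC[C@]1(C)C2=CCC[C@](C)(C[C@@H](O)C3=CC(=O)OC3O)[C@H]2CC[C@H]1C` differs from compound 2 at one place: a group of 7 heavy atoms (4 carbon, 3 oxygen; one five-membered non-aromatic ring with 1 hetero atom) in place of a group of 5 heavy atoms (4 carbon, 1 oxygen; one five-membered aromatic ring with 1 hetero atom), on a saturated chain carbon bound to an oxygen on a saturated carbon and a saturated chain carbon. Among the compounds with values here, the only measured step, a 2.0-fold lower number from compound 1 to compound 2 (0.29 log units; within the scatter), concerns the 1-methylethenyl chain and not the furan-3-yl group, so no measured step bears on this change. From the compounds shown here alone, what replaces the furan-3-yl is untested here, and the account can offer no more than a cautious expectation, kept wide. Compound 3 is expected to give 20000 nM in this assay, within 5000 nM to 80000 nM. The step of a 1.5-fold lower number from compound 2 to compound 3 (0.18 log units; within the scatter) that this estimate implies is expected to stay near the scatter.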

Compound 3, half-maximal inhibitory concentration: 5400 nM
Estimate against measurement, compound 3: 3.7-fold (0.57 log units) above; the range from low to high includes it.
By their numbers in this assay, from the lowest: compound 3; then compounds 2 and 1 (each within the scatter of the next).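

In this assay, this saturated chain carbon bound to an oxygen on a saturated carbon is the first place shown where a change goes beyond the scatter: the step is a 5.6-fold lower number from compound 2 to compound 3 (0.75 log units; beyond the scatter). The step in the side chain between the two earlier compounds stayed within the scatter, whereas here the aromatic furan-3-yl gives way to a five-membered non-aromatic ring with 1 hydrogen-bond donor and 3 hydrogen-bond acceptors, and the number still falls. No supporting data are available to account for this step.

The entering group differs from furan-3-yl in several features at once, so the compounds shown leave open which of them goes with the lower number. Also open, from the compounds shown here alone, is how a phenyl ring or a carboxylic acid would fare at this place, and whether the new ring gives a similar step on the core of compound 1.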